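The source may report more compounds than this note shows. Statements on the series, on what has been measured and on what is new or still open speak of the compounds shown alone.

Of the compounds shown here, two have been measured so far in an assay on microsomes from brain for inhibition of Fatty-acid amide hydrolase 1 (Rattus norvegicus), read by fluorescence and HPLC, with a stated time of 45 min; on this read-out higher numbers stand for weaker inhibition and lower numbers for stronger inhibition. Compound 1 `O=C(COc1ccc(Oc2ccccc2)cc1)Cn1ncc2cc(C(=O)O)ccc21` gives 55 nM in this assay, and compound 2 `O=C(COc1ccc(Oc2ccccc2)cc1)Cn1ncc2cc(NC(=O)CO)ccc21` gives 5400 nM. Going by the values given here, compound 2 therefore stands at the higher of the two numbers, and the one measured step reads a 98-fold higher number from compound 1 to compound 2 (1.99 log units; beyond the scatter). Compound 3 `O=C(COc1ccc(Oc2ccccc2)cc1)Cn1ncc2cc(NC(=O)Oc3ccccc3)ccc21` has not yet been measured. It differs from compound 2 in one place: phenoxy in place of hydroxymethyl on a carbonyl carbon. Among the compounds with values here, no measured step covers this exact exchange. Within the data shown here, the only step available, which also altered the group hanging from the same aromatic carbon, moved the number far beyond the scatter, so whatever sits at this position clearly matters, and a large step in either direction is possible here. Compound 3 is expected to give about 150 nM, with a plausible range from 15 nM to 2500 nM. That estimate means an expected step of a 36-fold lower number from compound 2 to compound 3 (1.56 log units; beyond the scatter) in this assay.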

Compound 3, half-maximal inhibitory concentration: 2100 nM
The estimate for compound 3 lay 14-fold (1.15 log units) below the measured number; low and high end bracket the measured number.
By their numbers in this assay, from the lowest: compound 1; then compound 3; then compound 2.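

In this assay, phenoxy in place of hydroxymethyl on the carbonyl carbon gives a 2.6-fold lower number from compound 2 to compound 3 (0.41 log units; beyond the scatter) and so brings only a modest gain, even though the entering group carries a six-membered aromatic ring. Set against the carboxy group, (phenoxycarbonyl)amino still gives a 38-fold higher number from compound 1 to compound 3 (1.58 log units; beyond the scatter) and so leaves most of the large loss seen with compound 2 in place, which means that neither group on the amide-type nitrogen comes close to compound 1. Nothing available here explains these differences.

Going by these compounds, what remains open is whether a smaller group on that carbonyl carbon, such as methoxy, or a longer chain there would shift the number further. It is also unknown how a plain amine or a sulfonic acid on the aromatic carbon would compare with the carboxy group.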